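A Catechol Swap on a Compound at the Limit

A few compounds are considered here, and "the series" means these few. Any claim that something is new, unique, unknown or untested is made for them only; others in the source may bear on it.

- compound 1 `O=S(=O)(NCCNC(=S)Nc1cccc(Cl)c1)c1ccc(-c2ccccc2OCc2cccc(O)c2)s1`: 5800 nM
- compound 2 `O=C(NCCNS(=O)(=O)c1ccc(-c2ccccc2OCc2cccc(O)c2)s1)Nc1cc(Cl)cc(Cl)c1`: > 50000 nM

In a functional assay on RS4-11 cells (Homo sapiens) for inhibition, read by CCK-8 assay, with a stated time of 48 h (a lower number here means a stronger inhibitor, a higher number a weaker inhibitor), compound 2 gives > 50000 nM, which is a limit and not a number. It therefore stands at the limit of > 50000 nM in this assay, at which 1 of the 2 values shown sits, and its true position is not known.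

Compound 3 `O=C(NCCNS(=O)(=O)c1ccc(-c2ccccc2Oc2ccc(O)c(O)c2)s1)Nc1cc(Cl)cc(Cl)c1` differs from compound 2 at one place: 3,4-dihydroxyphenyl in place of 3-hydroxybenzyl on an oxygen on an aromatic ring. In words, 3,4-dihydroxyphenyl replaces 3-hydroxybenzyl on an oxygen on an aromatic ring.

For the measured compounds named here, only one measured step is available, an at least 8.6-fold higher number from compound 1 to compound 2 (0.93 log units; beyond the scatter). That change lies on an amine nitrogen, not on this oxygen, so it gives no direct measure of the new change. Going by the values given here, it shows only that a single change in this set can move the read-out beyond the scatter. Compound 1, at 5800 nM, shows that a compound of this kind can return a number in this assay.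

A modest move towards a lower number is therefore expected, although compound 3 may well remain at the limit. The expected change is an at least 2.7-fold lower number from compound 2 to compound 3 (0.44 log units; beyond the scatter). For compound 3 the estimated value is 18000 nM, with an expected range of 4000 nM to 50000 nM.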

Compound 3, half-maximal inhibitory concentration: 4500 nM
Compound 3: the middle estimate sits 4.0-fold (0.60 log units) above what was measured, and the stated range covers the measured number.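

In this assay, the group on this oxygen proves able to bring a compound off the limit: the change from 3-hydroxybenzyl to 3,4-dihydroxyphenyl gives an at least 11-fold lower number from compound 2 to compound 3 (1.04 log units; beyond the scatter), and compound 3 returns a true number. For the compounds shown here, the only earlier step, an at least 8.6-fold higher number from compound 1 to compound 2 (0.93 log units; beyond the scatter), lay on an amine nitrogen, so this is the first sign that the far end of the molecule, on the oxygen on an aromatic ring, can also move the read-out beyond the scatter. The size of the new step is only a lower bound, as its starting point, compound 2, is a limit and not a number: the limit of > 50000 nM in this assay, at which 1 of the 3 values shown sits.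

The compounds shown do not separate the two parts of this swap, the change from benzyl to phenyl and the added hydroxy group, so it remains open which of them carries the step. As far as these compounds go, it also remains open whether an unsubstituted phenyl, or a phenyl ring bearing a carboxylic acid in place of the hydroxy groups, would keep the read-out off the limit in this assay.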